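A Methoxy Group on the Anilino Ring

The source may report more compounds than this note shows. Statements on the series, on what has been measured and on what is new or still open speak of the compounds shown alone.

Compound 3 `O=C(Nc1ccccc1)c1c(O)c2cccnc2n(-c2ccccc2)c1=O` is the anilino member of a small set that shares one core and differs only in the group on the carbonyl carbon. In a functional assay on the whole organism for inhibition, with Rattus norvegicus as the target, read by paw edema, at a dose of 100 mg/kg by the oral route (on this read-out lower numbers stand for less inhibition and higher numbers for more inhibition at the one dose given (going by the name of the read-out)), compound 3 gives 4.6%, the second highest of the three numbers. Its nearest neighbour is compound 2 `O=C(NCc1ccccc1)c1c(O)c2cccnc2n(-c2ccccc2)c1=O`, which gives 1.6% in this assay, and the step of a number 3 percentage points higher from compound 2 to compound 3 (within the scatter) lies within the scatter. The furthest is compound 1 `CCOC(=O)c1c(O)c2cccnc2n(-c2ccccc2)c1=O`, the ethyl ester, which gives 23.5% in this assay; the steps of a number 21.9 percentage points lower from compound 1 to compound 2 (beyond the scatter) and a number 18.9 percentage points lower from compound 1 to compound 3 (beyond the scatter) are both beyond the scatter.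

Compound 4 `COc1ccc(NC(=O)c2c(O)c3cccnc3n(-c3ccccc3)c2=O)cc1` is compound 3 with methoxy in place of hydrogen on an aromatic carbon. Going by the values given here, no measured step alters a group on the anilino ring. Among the compounds with values here, the only step touching the amide substituent, a number 3 percentage points higher from compound 2 to compound 3 (within the scatter), is within the scatter, while the two larger steps concern the ester-to-amide exchange and do not bear on a methoxy group. Compound 4 is therefore expected to show no step beyond the scatter, a number 1.4 percentage points higher from compound 3 to compound 4 (within the scatter). For compound 4 the estimate is 6%, with a range from 0% to 20%.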

Compound 4, a percentage reported as inhibition, in the whole organism at one dose (the size of the read-out at that dose, not a potency): 0.3%
Estimate against measurement, compound 4: 5.7 percentage points above, and the stated range covers the measured number.
By their numbers in this assay, from the lowest: compounds 4, 2 and 3 (each within the scatter of the next); then compound 1.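

In this assay, going by these compounds alone, the anilino ring itself is altered for the first time, and methoxy in place of hydrogen, para to a large group, gives a number 4.3 percentage points lower from compound 3 to compound 4 (within the scatter), so this change at this position shows no step beyond the scatter. The step of a number 1.3 percentage points lower from compound 2 to compound 4 (within the scatter) places the 4-methoxyphenyl amide with the benzyl and phenyl amides, whereas a number 23.2 percentage points lower from compound 1 to compound 4 (beyond the scatter) shows that the ethyl ester also stands apart from this third amide. Nothing measured here gives a reason for any of these numbers.

As far as these compounds go, whether a chlorine atom, a nitro group or a carboxylic acid at this position on the anilino ring would give a step beyond the scatter remains open. Also open, from the compounds shown here alone, is whether a longer ester, such as a butyl ester, would read differently from the ethyl ester.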